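Stripping Both Methoxy Groups From the Ketone Side

The source may hold more compounds than are shown below. What is called first, only, known or untested is meant among the compounds shown, and "the series" means these compounds.

Among the compounds with values here, compound 3 `COc1ccc(C(=O)/C=C/c2cc(-c3ccc(OC)c(OC)c3)n3nc(-c4ccccc4)cc3n2)cc1OC` gives 32500 nM in an ADME assay on HEK293 cells (Homo sapiens) for antiproliferative activity, read by MTT assay, with a stated time of 24 h (a higher number here means a weaker inhibitor, a lower number a stronger inhibitor), the lowest of the three numbers so far, yet compound 2 `COc1ccc(C(=O)/C=C/c2cc(-c3ccc(OC)c(OC)c3)n3nc(-c4ccccc4)cc3n2)cc1` at 40000 nM and compound 1 `COc1ccc(-c2cc(C(=O)/C=C/c3ccccc3)nc3cc(-c4ccccc4)nn23)cc1OC` at 64100 nM both sit within the scatter of it, so no ordering can be claimed. Compound 4 `COc1ccc(-c2cc(/C=C/C(=O)c3ccccc3)nc3cc(-c4ccccc4)nn23)cc1OC` differs from compound 3 by phenyl in place of 3,4-dimethoxyphenyl on a carbonyl carbon. Within the data shown here, two measured steps touch the methoxy groups of that 3,4-dimethoxyphenyl: a 1.6-fold lower number from compound 1 to compound 2 (0.20 log units; within the scatter) and a 1.2-fold lower number from compound 2 to compound 3 (0.09 log units; within the scatter). Both were small. Removing both methoxy groups roughly undoes those additions, so compound 4 is expected to give a slightly higher number, still a step inside the scatter, a 1.7-fold higher number from compound 3 to compound 4 (0.23 log units; within the scatter). Compound 4 is therefore estimated at 55000 nM, with a likely range from 25000 nM to 120000 nM.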

Compound 4, half-maximal inhibitory concentration: 51200 nM
Compound 4: middle estimate off by 1.1-fold (0.03 log units), on the high side, and the stated range covers the measured number.
By their numbers in this assay, from the lowest: compounds 3, 2, 4 and 1 (each within the scatter of the next).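

Replacing 3,4-dimethoxyphenyl with phenyl on the carbonyl carbon removes both methoxy groups at once, yet the result in this assay stays inside the scatter (a 1.6-fold higher number from compound 3 to compound 4 (0.20 log units; within the scatter)). Removing a single methoxy group does the same (a 1.3-fold higher number from compound 2 to compound 4 (0.11 log units; within the scatter)), so neither methoxy group is shown to matter here. Replacing (2-phenylethenyl)carbonyl with 2-benzoylethenyl on an aromatic carbon also stays inside it (a 1.3-fold lower number from compound 1 to compound 4 (0.10 log units; within the scatter)). Nothing measured here explains why these numbers lie so close. On these data alone, whether an amine or a carboxylic acid on that phenyl would give a number beyond the scatter remains open.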